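The compounds below may be only part of what the source reports. "The series", "measured", "known", "first", "only" and "open" are said of these compounds alone.

Three compounds carrying the same amide core were measured in a functional assay on HeLa cells (Homo sapiens) for antiproliferative activity, read by CCK-8 assay, with a stated time of 72 h, tested at 2 uM; on this read-out lower numbers stand for a weaker effect and higher numbers for a stronger effect at the one concentration tested. Compound 1, `Nc1ccccc1NC(=O)c1ccc(CSC(=S)N2CCc3cc([N+](=O)[O-])ccc32)cc1`, gives 32.6%. Compound 2, `Nc1ccccc1NC(=O)c1ccc(CSC(=S)N2CCc3ccc([N+](=O)[O-])cc32)cc1`, gives 45.7%. Compound 3, `COc1ccc(N2CCN(C(=S)SCc3ccc(C(=O)Nc4ccccc4N)cc3)CC2)cc1`, gives 39.4%. On these three numbers compound 3 stands second, yet its gap to compound 2 and its gap to compound 1 both fall within the usual scatter of this kind of measurement, so the three cannot be separated with confidence.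

Compound 4, `CN1CCN(C(=S)SCc2ccc(C(=O)Nc3ccccc3N)cc2)CC1`, has not been measured. It differs from compound 3 in one place: methyl in place of 4-methoxyphenyl on an amine nitrogen in a ring. Going by the values given here, no measured pair in this set shows what such a change does, so the direction of the step cannot be taken from the data. The step from compound 3 to compound 4 is therefore expected to be small, a number 6.4 percentage points lower from compound 3 to compound 4 (within the scatter), perhaps a slight weakening but not clearly beyond the scatter. Compound 4 is accordingly estimated at 33% in this assay, with a likely range from 18% to 48%.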

Compound 4, a percentage reported as inhibition, at one concentration (the size of the read-out at that concentration, not a potency): 52.6%
Compound 4: middle estimate off by 19.6 percentage points, on the low side, and the stated range ends below it.
By their numbers in this assay, from the lowest: compounds 1, 3, 2 and 4 (each within the scatter of the next, the first and the last beyond it).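

In this assay, going by these compounds alone, methyl in place of 4-methoxyphenyl on the amine nitrogen of the six-membered non-aromatic ring with 2 nitrogen gives a number 13.2 percentage points higher from compound 3 to compound 4 (beyond the scatter), the first step in this set that can be read at a single place. It shows that this position tolerates a large change: the group shrinks from 8 heavy atoms to 1 and loses its aromatic ring, yet the number does not fall. The 4-methoxyphenyl group is therefore not required for the effect seen with this pair at the one concentration tested. No measurement shown here explains why the smaller group gives the higher number.

This single pair leaves open whether the step follows the loss of the aromatic ring or of the methoxy group, which an unsubstituted phenyl could separate. It also leaves open how an ethyl group, a longer chain or a plain hydrogen on that nitrogen would compare with methyl.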